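The compounds below may be only part of what the source reports. "The series", "measured", "known", "first", "only" and "open" are said of these compounds alone.

Measured so far in a functional assay on HGC-27 cells (Homo sapiens) for cytotoxicity, read by MTT assay, with a stated time of 72 h; on this read-out higher numbers stand for weaker inhibition and lower numbers for stronger inhibition:
- compound 1 `O=C1C=CCC/C1=C\C=C\c1ccccc1` gives 4500 nM
- compound 2 `CC(=C\c1ccccc1)/C=C1\CCC=CC1=O` gives 5200 nM
- compound 3 `O=C1C=CCC/C1=C\C=C\c1ccc(Cl)cc1` gives 4800 nM

Compound 1 with 4500 nM stands level with compound 2 and compound 3, as both steps away from it lie within the scatter.

The open question is compound 4 `O=C1C=CCC/C1=C\C=C\c1ccccc1[N+](=O)[O-]`, which is compound 1 with nitro in place of hydrogen on an aromatic carbon, ortho to a large group (nitro in place of hydrogen on an aromatic carbon). Within the data shown here, two measured steps bear on this change. Chloro also replaces hydrogen on an aromatic carbon, and that swap gives a 1.1-fold higher number from compound 1 to compound 3 (0.03 log units; within the scatter) as the closest guide. Methyl on the chain gives a 1.2-fold higher number from compound 1 to compound 2 (0.06 log units; within the scatter) and is a weaker guide, since it changes a different part of the molecule.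

Neither step leaves the scatter, so no step beyond the scatter is expected in this assay for this change. Among the measured compounds shown here, no measured compound carries nitro, however, so the range has to stay wide. The expected step is a 1.1-fold lower number from compound 1 to compound 4 (0.05 log units; within the scatter) at this estimate. Compound 4 is estimated at 4000 nM with an expected range from 1800 nM to 8000 nM in this read-out.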

Compound 4, half-maximal inhibitory concentration: 4400 nM
Beside the measured number, compound 4's estimate is 1.1-fold (0.04 log units) below it; the measured number falls inside the stated range.
By their numbers in this assay, from the lowest: compounds 4, 1, 3 and 2 (each within the scatter of the next).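

In this assay there is a 1.0-fold lower number from compound 1 to compound 4 (0.01 log units; within the scatter) when nitro replaces hydrogen on an aromatic carbon, ortho to a large group. Until now, chloro was the only group shown on this aromatic ring, so this result adds something new: a larger group of three heavy atoms, with two hydrogen-bond acceptors, also leaves the number level with that of the unsubstituted compound. Nothing available here explains why the number holds level under this change.

On these data alone, whether an amine or a carboxylic acid on the same aromatic carbon would also leave the number level remains open. So does whether a change elsewhere in the shared core, such as a longer chain between the two rings, would produce a step beyond the scatter.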